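Aryl swaps on the hydrazone of compound 1

The compounds below may be only part of what the source reports. "The series", "measured", "known", "first", "only" and "open" are said of these compounds alone.

Measured compounds:
compound 1 `CN(C)CCn1cnnc1-c1cc(Oc2ccc(NC(=O)N/N=C/c3ccc(F)cc3Cl)cc2F)ccn1` — 870 nM in a functional assay on MKN-45 cells (Homo sapiens) for cytotoxicity, read by MTT assay, with a stated time of 72 h; on this read-out higher numbers stand for weaker inhibition and lower numbers for stronger inhibition
compound 2 `CN(C)CCn1cnnc1-c1cc(Oc2ccc(NC(=O)N/N=C/c3ccc(O)cc3)cc2F)ccn1` — 820 nM
compound 3 `CN(C)CCn1cnnc1-c1cc(Oc2ccc(NC(=O)N/N=C/c3ccc(O)c(Br)c3)cc2F)ccn1` — 1860 nM

In this assay compound 1 holds the second highest of the three numbers, close to compound 2 and furthest from compound 3. Exchanging the aryl group on the hydrazone carbon gave a 1.1-fold lower number from compound 1 to compound 2 (0.03 log units; within the scatter), whereas a 2.1-fold higher number from compound 1 to compound 3 (0.33 log units; beyond the scatter); within the hydroxyphenyl pair, a 2.3-fold higher number from compound 2 to compound 3 (0.36 log units; beyond the scatter).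

Compound 4 `CN(C)CCn1cnnc1-c1cc(Oc2ccc(NC(=O)N/N=C/c3c(O)ccc4ccccc34)cc2F)ccn1` differs from compound 1 by 2-hydroxynaphthalen-1-yl in place of 2-chloro-4-fluorophenyl on a carbon with a double bond to nitrogen. The two measured swaps at this position bear on the step: a plain hydroxyphenyl left the number where it was, and a larger bromo-bearing ring raised it modestly. Compound 4 carries the largest group yet at this position, so a modest rise in the number, or none beyond the scatter, is expected: a 1.5-fold higher number from compound 1 to compound 4 (0.17 log units; within the scatter). Compound 4 is therefore estimated at 1300 nM, with a range from 550 nM to 3200 nM.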

Compound 4, half-maximal inhibitory concentration: 2020 nM
Compound 4: middle estimate off by 1.6-fold (0.19 log units), on the low side; the range from low to high includes it.
By their numbers in this assay, from the lowest: compounds 2 and 1 (each within the scatter of the next); then compounds 3 and 4 (each within the scatter of the next).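

In this assay, the second fused ring with its hydroxyl gives a 2.3-fold higher number from compound 1 to compound 4 (0.37 log units; beyond the scatter), and the hydroxyl alone does not set the number, since the 4-hydroxyphenyl group of compound 2 stands apart with a 2.5-fold higher number from compound 2 to compound 4 (0.39 log units; beyond the scatter). Two quite different hydroxyl-bearing groups land together, with a 1.1-fold higher number from compound 3 to compound 4 (0.04 log units; within the scatter), so the larger aryl groups shown offer no gain here. No data on the cause of these steps are at hand. Open, as far as these compounds go, is whether naphthalen-1-yl without the hydroxyl matches compound 4, and whether an amine or a carboxylic acid on the aryl ring brings the number under that of compound 2.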